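The compounds below may be only part of what the source reports. "The series", "measured", "known", "first", "only" and "open" are said of these compounds alone.

Compound 1 `Cc1coc(Cn2nc3ccc(-c4ccc(OC(F)(F)F)cc4)cn3c2=O)n1`: 2.67 h
Compound 2 `O=c1n(Cc2noc(CO)n2)nc2ccc(-c3ccc(Oc4ccc(F)cc4)cc3)cn12`: 3.02 h

Both were measured in an ADME assay on microsomes (Canis lupus familiaris) for metabolic stability; on this read-out higher numbers stand for a longer-lived compound and lower numbers for a shorter-lived compound. Of the two numbers, compound 2 has the larger, but its gap to compound 1 lies within the usual scatter, so the two cannot be told apart on this read-out. Compound 3 `Cc1nc(Cn2nc3ccc(-c4ccc(Oc5ccc(F)cc5)cc4)cn3c2=O)no1` has not been measured yet. It differs from compound 2 in one place: hydrogen in place of hydroxy on a saturated chain carbon bound to an aromatic carbon. Among the measured compounds shown here, no measured pair shows this change, so nothing here tells how large a step it brings. The estimate therefore assumes an expected step of a 1.1-fold lower number from compound 2 to compound 3 (0.03 log units; within the scatter) that stays within the scatter. Compound 3 is expected to give about 2.8 h, somewhere between 1.3 h and 6 h.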

Compound 3, half-life: 2.78 h
Compound 3: the middle estimate sits 1.0-fold (0.00 log units) above what was measured, within the range that was stated.
By their numbers in this assay, from the lowest: compounds 1, 3 and 2 (each within the scatter of the next).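

In this assay, the change from hydroxymethyl to methyl gives a 1.1-fold lower number from compound 2 to compound 3 (0.04 log units; within the scatter), so at this position the hydroxy group can be lost with no readable effect on half-life. Among the compounds shown here, this is the first measured step at this position, though it is only a single pair of compounds. No measurement shown here explains why the step is so small.

On these data alone, it remains open whether an amine, a carboxylic acid or a longer chain at this position would also leave the half-life within the scatter. A single step cannot show whether larger groups here would matter.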